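Aryl acid variations in a linked bis-aryl ketone series

The compounds below may be only part of what the source reports. "The series", "measured", "known", "first", "only" and "open" are said of these compounds alone.

Measured compounds:
compound 1 `Cc1c(OCCCCOc2ccc(C(=O)O)cc2Cl)ccc(C(=O)CC2CCCC2)c1O` gives 27.4%
compound 2 `COc1cc(C(=O)O)ccc1OCCCCOc1ccc(C(=O)CC(C)C)c(O)c1C` gives 73.9%
compound 3 `Cc1c(OCCCCOc2ccc(C(=O)O)cc2Cl)ccc(C(=O)CC(C)C)c1O` gives 62.9%

In an assay on HEK293 cells for positive allosteric modulation of metabotropic glutamate receptor 3 (Rattus norvegicus), read by thallium flux, with a stated time of 2.5 min (on this read-out higher numbers stand for larger maximal responses and lower numbers for smaller maximal responses), compound 3 stands second highest of the three numbers; its nearest neighbour is compound 2, reached by a number 11 percentage points lower from compound 2 to compound 3 (beyond the scatter), and the furthest is compound 1, separated by a number 35.5 percentage points higher from compound 1 to compound 3 (beyond the scatter). Compound 4 `Cc1c(OCCCCOc2ccccc2C(=O)O)ccc(C(=O)CC(C)C)c1O` has not been measured. It differs from compound 3 by 2-carboxyphenyl in place of 4-carboxy-2-chlorophenyl on an oxygen on a saturated carbon. For the measured compounds named here, the only measured step on the aryl-acid side is the one from compound 2 to compound 3, modest in size and beyond the scatter; no step alters where the carboxy group sits. A modest step in this assay is therefore expected, direction uncertain, with a wider range than usual. Compound 4 is estimated at 55% (range 30% to 80%), meaning an expected step of a number 7.9 percentage points lower from compound 3 to compound 4 (within the scatter).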

Compound 4, largest response reached (reported as percent of maximum), in percent of the reference or control that the assay uses: 28.1%
Compound 4: the middle estimate sits 26.9 percentage points above what was measured, outside the stated range (below it).
By their numbers in this assay, from the lowest: compounds 1 and 4 (each within the scatter of the next); then compound 3; then compound 2.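

In this assay, the aryl acid side is more sensitive than the chloro-for-methoxy step suggested: a number 34.8 percentage points lower from compound 3 to compound 4 (beyond the scatter), against a number 11 percentage points lower from compound 2 to compound 3 (beyond the scatter) for that earlier change. This single swap both relocates the carboxy group and removes the chloro, so the size of the step cannot be divided between the two.

Open, from the compounds shown here alone, is how each of those two changes reads alone, and whether a tetrazole or an amide can stand in for the carboxylic acid. Nothing at hand explains the drop.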